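The source may report more compounds than this note shows. Statements on the series, on what has been measured and on what is new or still open speak of the compounds shown alone.

Compound 2 `CCCCCCCCc1cc2cn([C@H]3C[C@H](O)[C@@H](CO)O3)c(=O)nc2o1` is one of three close relatives built on a shared core. In a functional assay on HEL cells (Homo sapiens) for cytotoxicity, read by microscopy (a lower number here means that less compound is tolerated, a higher number that more compound is tolerated), compound 2 gives only a limit, > 50000 nM. Compound 1 `CCCCCc1cc2cn([C@H]3C[C@H](O)[C@@H](CO)O3)c(=O)nc2o1` likewise reaches only a limit in this assay, > 50000 nM. Compound 3 `C=CCCCCCCCCc1cc2cn([C@H]3C[C@H](O)[C@@H](CO)O3)c(=O)nc2o1` also reaches only a limit in this assay, > 50000 nM. The steps between these compounds therefore cannot be read: a step that the two limits leave unreadable from compound 1 to compound 2, a step that the two limits leave unreadable from compound 1 to compound 3 and a step that the two limits leave unreadable from compound 2 to compound 3 all fall between two limits, because of the limit of > 50000 nM in this assay, at which 3 of the 3 values shown sit. Compound 4 `C#CCCCCCCc1cc2cn([C@H]3C[C@H](O)[C@@H](CO)O3)c(=O)nc2o1` has not yet been measured. It differs from compound 2 by ethynyl in place of ethyl on a saturated chain carbon, six bonds along the chain from an aromatic carbon. For the measured compounds named here, of the measured steps, the one from compound 2 to compound 3 comes closest, since it also changes a group on a saturated chain carbon, eight bonds along the chain from an aromatic carbon, but its size is unreadable. These three values give no reading of how chain length or terminal unsaturation shifts what is tolerated. A step of a number no higher from compound 2 to compound 4 (the limit leaves the size open) is expected, meaning no readable change. Compound 4 is estimated at 50000 nM in this assay, within a range of 20000 nM to 100000 nM, and a limit is again the likely report.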

Compound 4, minimum cytotoxic concentration: > 200000 nM
Compound 4 was reported as a limit; the forecaster's own chance of this, stated with the estimate: 80%; at least 4.0-fold (0.60 log units) between middle value and limit.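

In this assay compound 4 also gives only a limit, > 200000 nM. Its steps from compound 1, compound 2 and compound 3 all join two limits and cannot be read. The compounds shown leave open at what concentration any of them becomes cytotoxic, and whether chain length or the ethynyl group changes that concentration.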